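This account rests on a few compounds, and the source may have more. Where it says the series, first, only, none or still open, it means among the compounds named here.

Measured so far, in a functional assay (B cells) with Mus musculus as the target; on this read-out higher numbers stand for an effect only at larger amounts of compound and lower numbers for an effect already at smaller amounts:

- compound 1, `[N-]=[N+]=NCC(O)Cn1c(=O)n(C2OC(CO)[C@@H](O)[C@H]2O)c2nc(N)nc(O)c21`: 39 uM
- compound 2, `C=CCn1c(=O)n(CCCCCCCC)c2nc(N)nc(O)c21`: 37 uM
- compound 3, `C=CCn1c(=O)n(CCCC)c2nc(N)nc(O)c21`: 2 uM

Compound 3 gives the lowest number of the three, and both other compounds lie beyond the usual scatter from it. Among the compounds with values here, the only step between two compounds that differ in one place is a 19-fold lower number from compound 2 to compound 3 (1.27 log units; beyond the scatter), a large step in which a long chain on the nitrogen of the shared core is cut back to a shorter one. Compound 1 carries different groups on both nitrogens of the core, so its value and that of compound 3 can only be compared as two numbers, with nothing tying the gap to a single change.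

Compound 4, `C=CCn1c(=O)n(Cc2ccccc2)c2nc(N)nc(O)c21`, is the next step from compound 3: phenyl in place of propyl on a saturated chain carbon bound to an aromatic nitrogen. Cut one bond further out, this reads butyl to benzyl. The step from compound 2 to compound 3 shows that what sits on this nitrogen can move the number strongly, and that a larger group there gave a higher number. Within the data shown here, a benzyl group is larger than butyl but smaller than octyl, and no measured compound carries a ring in this place, so the direction rests on that one step alone. In this assay compound 4 is therefore expected to give a moderately higher number than compound 3, by a 3.0-fold higher number from compound 3 to compound 4 (0.48 log units; beyond the scatter), with the estimate 6 uM and a wide range from 1.5 uM to 25 uM.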

Compound 4, concentration for half-maximal effect: 5 uM
For compound 4 the middle estimate is 1.2-fold (0.08 log units) above the measured one, within the range that was stated.
By their numbers in this assay, from the lowest: compound 3; then compound 4; then compounds 2 and 1 (each within the scatter of the next).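

Until now this nitrogen had carried only open chains, so the ring is what is new here: in this assay the change from butyl to benzyl gives a 2.5-fold higher number from compound 3 to compound 4 (0.40 log units; beyond the scatter) and so a phenyl ring on this saturated chain carbon brings only a modest rise in the number. Set against the long chain, the same ring gives a 7.4-fold lower number from compound 2 to compound 4 (0.87 log units; beyond the scatter) and this leaves compound 4 much closer to compound 3 than to compound 2 on this read-out. The three compounds now rank butyl, then benzyl, then octyl from the lowest number up, and none of them goes against that order, although three compounds are too few to call it a trend.

On these data alone, it remains open whether the ring itself matters or only the overall length of the group, which a straight hexyl chain or a saturated cyclohexylmethyl group in the same place could help to separate, and whether an amine or a carboxylic acid on the ring would move the number at all. Nothing available here explains why the benzyl group gives this result.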